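Sulfamoylphenyl Replaces Ethoxyphenyl on a Shared Core

The source may report more compounds than this note shows. Statements on the series, on what has been measured and on what is new or still open speak of the compounds shown alone.

Three compounds share one core and differ only in the aryl group on an aromatic nitrogen. Compound 1 `N#CC1=C(N)Oc2c(c3nc4ccccc4nc3c3ccccc23)C12C(=O)N(Cc1cnnn1-c1ccc(Cl)cc1)c1ccccc12` carries a 4-chlorophenyl; in a functional assay on A549 cells (Homo sapiens) for antiproliferative activity, read by MTT assay, with a stated time of 48 h (a lower number here means a stronger inhibitor, a higher number a weaker inhibitor), compound 1 reaches only the limit of > 50000 nM. Compound 2 `N#CC1=C(N)Oc2c(c3nc4ccccc4nc3c3ccccc23)C12C(=O)N(Cc1cnnn1-c1cccc(Cl)c1)c1ccccc12`, with a 3-chlorophenyl, gives 32600 nM in this assay, a step of an at least 1.5-fold lower number from compound 1 to compound 2 (0.18 log units; that floor lies within the scatter). Compound 3 `CCOc1ccccc1-n1nncc1CN1C(=O)C2(C(C#N)=C(N)Oc3c2c2nc4ccccc4nc2c2ccccc32)c2ccccc21` carries a 2-ethoxyphenyl, and its result in this assay is again only a limit, > 50000 nM. That move is an at least 1.5-fold higher number from compound 2 to compound 3 (0.18 log units; that floor lies within the scatter), while a step that the two limits leave unreadable from compound 1 to compound 3; the limit of > 50000 nM in this assay, at which 2 of the 3 values shown sit, shows how little these numbers can resolve. Compound 4 `N#CC1=C(N)Oc2c(c3nc4ccccc4nc3c3ccccc23)C12C(=O)N(Cc1cnnn1-c1cccc(S(N)(=O)=O)c1)c1ccccc12` makes the change (3-sulfamoylphenyl in place of 2-ethoxyphenyl on an aromatic nitrogen). With two of three neighbours at the limit and compound 2 only modestly inside it, compound 4 is expected to stay weak, an estimated at least 1.1-fold lower number from compound 3 to compound 4 (0.04 log units; that floor lies within the scatter). The estimated value of compound 4 in this assay is 45000 nM, within 18000 nM to 100000 nM.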

Compound 4, half-maximal inhibitory concentration: 44200 nM
Compound 4: middle estimate off by 1.0-fold (0.01 log units), on the high side, and the stated range covers the measured number.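

Sulfamoyl in place of chloro, a change that adds a hydrogen-bond donor, gives a 1.4-fold higher number from compound 2 to compound 4 (0.13 log units; within the scatter), so this swap yields no readable difference. The steps from the two limit compounds are only floors, an at least 1.1-fold lower number from compound 3 to compound 4 (0.05 log units; that floor lies within the scatter) and an at least 1.1-fold lower number from compound 1 to compound 4 (0.05 log units; that floor lies within the scatter), and they show no real gain either. These comparisons stay coarse because the values crowd against one ceiling: the limit of > 50000 nM in this assay, at which 2 of the 4 values shown sit.

Still open, from the compounds shown here alone, is whether an amine or a carboxylic acid on this phenyl ring would move the number beyond the scatter. Also open, going by these compounds, is whether a longer alkyl chain in place of the aryl group on the aromatic nitrogen would do so.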